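The source may hold more compounds than are shown below. What is called first, only, known or untested is meant among the compounds shown, and "the series" means these compounds.

Measured so far in an ADME assay on THLE3 cells (Homo sapiens) for cytotoxicity, read by resazurin assay, with a stated time of 48 h; on this read-out lower numbers stand for an effect already at smaller amounts and higher numbers for an effect only at larger amounts of compound:
- compound 1 `O=C1/C(=C/c2ccc(O)c(O)c2)SC(=S)N1c1ccc(O)cc1`: 16000 nM
- compound 2 `CNC(=O)Nc1ccc2nc(-c3ccco3)c(-c3ccco3)nc2c1`: > 100000 nM (a limit of the assay, not a number)

Compound 1 has a core of its own and gives a real number, 16000 nM. Compound 2 stands at a limit of this assay, > 100000 nM, so it has no exact value. That is the only starting point for the step followed here, and it is a weak one.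

Compound 3 `O=C(Nc1ccc2nc(-c3ccco3)c(-c3ccco3)nc2c1)N1CCCC1` keeps the shared core of compound 2 and carries pyrrolidin-1-yl in place of methylamino on a carbonyl carbon. Read one bond further out, (methylcarbamoyl)amino becomes ((pyrrolidin-1-yl)carbonyl)amino.

For the measured compounds named here, no measured pair shows what this swap does in this assay. The expectation is therefore modest: no change beyond the usual scatter, in either direction, and quite possibly another limit rather than a number. The expected size of the change is a number no higher from compound 2 to compound 3 (the limit leaves the size open). For compound 3 the estimated value is 100000 nM, with an expected range from 35000 nM to 200000 nM.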

Compound 3, half-maximal effective concentration: > 100000 nM
Compound 3: no number, only a limit (the forecaster's own chance of this, stated with the estimate: 60%); the middle value lies on the limit itself.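

In this assay compound 3 gives > 100000 nM, a limit of the assay and not a number. Compound 2 also stands at a limit, so no step can be read between compound 2 and compound 3. The compounds shown leave open whether pyrrolidin-1-yl in place of methylamino on a carbonyl carbon changes the read-out in this assay at all.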